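Fluoro for Methoxy on the Ethenyl Arm: Compound 4

This account rests on a few compounds, and the source may have more. Where it says the series, first, only, none or still open, it means among the compounds named here.

Measured so far in an ADME assay on PANC-1 cells (Homo sapiens) for cytotoxicity, read by MTT assay, with a stated time of 48 h; on this read-out lower numbers stand for stronger inhibition of growth and higher numbers for weaker inhibition of growth:
Compound 1 `O=C(/C=C\c1ccccc1O)N1N=C(c2ccncc2)OC1c1c[nH]c2ccccc12` gives > 30 ug/mL, which is a limit of the assay.
Compound 2 `O=C(/C=C\c1ccccc1[N+](=O)[O-])N1N=C(c2ccncc2)OC1c1c[nH]c2ccccc12` gives > 30 ug/mL, which is a limit of the assay.
Compound 3 `COc1ccc(/C=C\C(=O)N2N=C(c3ccncc3)OC2c2c[nH]c3ccccc23)cc1` gives > 30 ug/mL, which is a limit of the assay.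

Compound 3 therefore stands at the limit, the same point at which every measured value in this assay sits (the limit of > 30 ug/mL in this assay, at which 3 of the 3 values shown sit). No measured step can be read: the step from compound 1 to compound 2 a step that the two limits leave unreadable from compound 1 to compound 2, the step from compound 1 to compound 3 a step that the two limits leave unreadable from compound 1 to compound 3 and the step from compound 2 to compound 3 a step that the two limits leave unreadable from compound 2 to compound 3 are all left without a readable size by the two limits that bound them.

Compound 4 `O=C(/C=C\c1ccc(F)cc1)N1N=C(c2ccncc2)OC1c1c[nH]c2ccccc12` differs from compound 3 by fluoro in place of methoxy on an aromatic carbon. The steps into compound 3 also exchange the substituted phenyl on the ethenyl carbon, so they bear on this change, but their unreadable sizes give no direction. With nothing in the measured set rising above the limit, compound 4 is expected to remain there as well. Its estimated value in this assay is 45 ug/mL, within a range of 15 ug/mL to 150 ug/mL. The step this implies, a step that the limit leaves unreadable from compound 3 to compound 4, is expected to be none beyond the scatter.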

Compound 4, concentration for 50% growth inhibition: > 30 ug/mL
Compound 4: a limit, no number (the forecaster's own chance of this, stated with the estimate: 80%); the middle value does not contradict the limit.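

Among the compounds shown here, no step from compound 1, compound 2 or compound 3 to compound 4 can be read, and every compound shown sits at the same limit: the limit of > 30 ug/mL in this assay, at which 4 of the 4 values shown sit. The compounds shown leave open how strongly any of them inhibits growth of these cells, and whether any change on the ethenyl arm shifts that inhibition at all.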